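The source may report more compounds than this note shows. Statements on the series, on what has been measured and on what is new or still open speak of the compounds shown alone.

Compound 1 `COc1ccc(Cn2ccc3nc(-c4ccccc4)nc-3c2)cc1`, compound 2 `Fc1ccccc1Cn1ccc2nc(-c3ccccc3)nc-2c1` and compound 3 `Clc1ccccc1Cn1ccc2nc(-c3ccccc3)nc-2c1` share one core and differ only in the aryl group on a saturated chain carbon bound to an aromatic nitrogen. In an ADME assay on MDBK cells (Bos taurus) for cytotoxicity (a higher number here means that more compound is tolerated, a lower number that less compound is tolerated), compound 1 gives > 100000 nM as a limit of the assay. Compound 2 gives > 100000 nM as a limit too. Compound 3 likewise gives > 100000 nM as a limit and has no number of its own. The series therefore rests on one finding: the limit of > 100000 nM in this assay, at which 3 of the 3 values shown sit, and nothing else.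

Compound 4 `Clc1cccc(Cn2ccc3nc(-c4ccccc4)nc-3c2)c1` carries 3-chlorophenyl in place of 2-chlorophenyl on that carbon: 3-chlorophenyl in place of 2-chlorophenyl on a saturated chain carbon bound to an aromatic nitrogen is the whole change. Within the data shown here, three measured steps bear on it: a step that the two limits leave unreadable from compound 1 to compound 2 and a step that the two limits leave unreadable from compound 1 to compound 3 and a step that the two limits leave unreadable from compound 2 to compound 3 all leave their size unknown. None of the three compounds gave a number, so what is expected in this assay is a number no higher from compound 3 to compound 4 (the limit leaves the size open) with no direction favoured and nothing beyond the scatter. Compound 4 is estimated at 100000 nM within a range from 50000 nM to 200000 nM and will most likely be reported as a limit again.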

Compound 4, half-maximal cytotoxic concentration: > 100000 nM
Compound 4 was reported as a limit; the forecaster's own chance of this, stated with the estimate: 85%; the middle value sits exactly at the limit.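

In this assay, the steps joining compound 4 to compound 1, compound 2 and compound 3 cannot be read, and the series still rests on one finding: the limit of > 100000 nM in this assay, at which 4 of the 4 values shown sit.

The compounds shown leave open where any of them reaches its half-maximal cytotoxic concentration, and whether the aryl group matters at all.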